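A few compounds are considered here, and "the series" means these few. Any claim that something is new, unique, unknown or untested is made for them only; others in the source may bear on it.

Compound 1 `NC1=NC2(CCOCC2)N(OCCCOc2ccc(Cl)cc2)C(N)=N1`: > 90%
Compound 2 `NC1=NC2(CCSCC2)N(OCCCOc2ccc(Br)cc2)C(N)=N1`: > 90%
Compound 3 `NC1=NC2(CCSCC2)N(OCCCOc2cc(Cl)c(Cl)cc2Cl)C(N)=N1`: 84.4%

In an assay on isolated protein for inhibition of Dihydrofolate reductase (Homo sapiens), read by spectrophotometry, using NADPH, with stated times of 5 s and 6 min, tested at 5 uM (on this read-out lower numbers stand for a weaker effect and higher numbers for a stronger effect at the one concentration tested), compound 1 gives > 90%, which is a limit of the assay rather than a number. Compound 2 also sits at that limit, so the limit of > 90% in this assay, at which 2 of the 3 values shown sit, leaves compound 1 no room to be told apart from it. Compound 4 `NC1=NC2(CCOCC2)N(OCCCOc2ccc(Cl)cc2Cl)C(N)=N1` differs from compound 1 by chloro in place of hydrogen on an aromatic carbon. Among the measured compounds shown here, the one measured step that bears on this change, more chlorines on the phenyl ring, is a number at least 5.6 percentage points lower from compound 2 to compound 3 (that floor lies within the scatter), and that step stays within the usual scatter. For compound 4 a step of about a number at least 2 percentage points lower from compound 1 to compound 4 (that floor lies within the scatter) is therefore expected, downward if anything but not beyond the scatter. Compound 4 is estimated at 88%, between 78% and 96%.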

Compound 4, a percentage reported as inhibition, at one concentration (the size of the read-out at that concentration, not a potency): > 90%
Compound 4: only a limit was reported (the forecaster's own chance of this, stated with the estimate: 40%); middle value at least 2 percentage points away from the limit.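

Compound 1 and compound 4 both sit at a limit of the assay rather than at a number, so no step can be read between them: the limit of > 90% in this assay, at which 3 of the 4 values shown sit.

Going by these compounds, whether chloro in place of hydrogen on an aromatic carbon changes the inhibition in this assay stays open.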